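Ester Variation on the Furanyl Dihydropyrimidinone Series

The source may hold more compounds than are shown below. What is called first, only, known or untested is meant among the compounds shown, and "the series" means these compounds.

Compound 1 `CC1=C(C(=O)OCc2ccccc2)C(c2ccoc2)NC(=O)N1` gives 1% in an assay on membranes from HeLa cells for displacement of a labelled ligand from adenosine receptor A3 (Homo sapiens), read by scintillation counting, with a stated time of 180 min, tested at 1 uM; on this read-out higher numbers stand for more inhibition at the one concentration tested (going by the name of the read-out) and lower numbers for less inhibition. Compound 2 `CCCOC(=O)C1=C(C)N(C)C(=O)NC1c1ccoc1` gives 16% and compound 3 `CC1=C(C(=O)OCC(C)C)C(c2ccoc2)NC(=O)N1C` gives 16%. Compound 3 thus stands level with compound 2, the two together at the top of the three numbers, and lies a clear distance above compound 1. Going by the values given here, the one single-point step measured so far, no change at the digits printed from compound 2 to compound 3 (within the scatter), touches the ester chain and shows that lengthening that chain by one branch leaves the read-out where it was.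

Compound 4 `CC1=C(C(=O)OCc2ccccc2)C(c2ccoc2)NC(=O)N1C` differs from compound 3 by phenyl in place of isopropyl on a saturated chain carbon bound to an oxygen next to a carbonyl group. Among the compounds with values here, the step from compound 2 to compound 3 is the only measured step on the ester side and bears on it only loosely, as it swaps one saturated chain for another rather than bringing in a ring. Compound 1 carries the same benzyl ester as compound 4 but differs from compound 3 in more than one place, so its low value cannot be read as the effect of the ester alone; it does, however, weigh against expecting a rise. A modest fall, a number 6 percentage points lower from compound 3 to compound 4 (within the scatter), is therefore expected, within or just beyond the scatter. Compound 4 is estimated at 10%, in the range 0% to 25%.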

Compound 4, a percentage reported as inhibition, at one concentration (the size of the read-out at that concentration, not a potency): 25%
The estimate for compound 4 lay 15 percentage points below the measured number; low and high end bracket the measured number.
By their numbers in this assay, from the lowest: compound 1; then compounds 2, 3 and 4 (each within the scatter of the next).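

In this assay, going by these compounds alone, the ring enters the ester chain for the first time with methyl on the amide-type nitrogen in a ring, and a number 9 percentage points higher from compound 3 to compound 4 (within the scatter) and a number 9 percentage points higher from compound 2 to compound 4 (within the scatter) show that phenyl in place of isopropyl or of ethyl keeps the number within the scatter of the saturated chains. The benzyl ester therefore stands level with the propyl and isobutyl esters at this place on the evidence of these three compounds. Within the data shown here, with the benzyl ester held constant, the change of methyl in place of hydrogen on that nitrogen gives the first step beyond the scatter, a number 24 percentage points higher from compound 1 to compound 4 (beyond the scatter), so the low number of compound 1 goes with the hydrogen on that nitrogen and not with the benzyl group. No measurement at hand offers a reason for this step.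

Going by these compounds, whether methyl in place of hydrogen on that nitrogen gives a similar step with the propyl or isobutyl esters remains open. Also open is how a longer chain, a substituted benzyl group or a carboxylic acid at the ester place would read, and how any of these compounds behaves across a range of concentrations.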